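Aminophenyl swapped for difluorophenyl at the carbonyl

The source may report more compounds than this note shows. Statements on the series, on what has been measured and on what is new or still open speak of the compounds shown alone.

In a functional assay on Hs-578T cells (Homo sapiens) for cytotoxicity, read by sulforhodamine B assay, with a stated time of 48 h, tested at 0.01 uM (a lower number here means a stronger effect, a higher number a weaker effect of the compound at the concentration tested), compound 1 `COc1cc(-c2cc(/C=C/C(=O)c3ccc(N)cc3)[nH]n2)cc(OC)c1OC` gives 95%, and compound 2 `COc1ccc(-c2cc(/C=C/C(=O)c3ccc(N)cc3)[nH]n2)cc1OC` gives 98%; the two stand together, with the step of a number 3 percentage points higher from compound 1 to compound 2 (within the scatter) for hydrogen in place of methoxy on an aromatic carbon. Compound 3 `COc1cc(-c2cc(/C=C/C(=O)c3ccc(F)c(F)c3)[nH]n2)cc(OC)c1OC` differs from compound 1 by 3,4-difluorophenyl in place of 4-aminophenyl on a carbonyl carbon. Among the measured compounds shown here, no measured step touches the ring on the carbonyl carbon, so the one step in hand gives no guide to this change, and nothing supports a move beyond the scatter. Compound 3 is therefore expected near compound 1, at 96%, within 84% to 106%. The expected step is a number 1 percentage points higher from compound 1 to compound 3 (within the scatter).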

Compound 3, a percentage reported as activity, at one concentration (the size of the read-out at that concentration, not a potency): 98%
For compound 3 the middle estimate is 2 percentage points below the measured one, within the range that was stated.
By their numbers in this assay, from the lowest: compounds 1, 2 and 3 (each within the scatter of the next).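

In this assay, 3,4-difluorophenyl in place of 4-aminophenyl on the carbonyl carbon gives a number 3 percentage points higher from compound 1 to compound 3 (within the scatter). This is the only step shown at this position, and at this single concentration it does not separate the two rings, although the hydrogen-bond donor and acceptor counted on 4-aminophenyl are absent from 3,4-difluorophenyl. Nothing available bears on the reason for this result.

As far as these compounds go, whether a dimethylamino group or a carboxylic acid on this ring would depart from compound 1 remains open. Also open, from the compounds shown here alone, is whether 4-aminophenyl and 3,4-difluorophenyl would separate at higher concentrations.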